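The source may hold more compounds than are shown below. What is called first, only, known or untested is meant among the compounds shown, and "the series" means these compounds.

Compound 3, `C=C[C@@](C)(O)CC[C@H]1C(=C)CC[C@@H]2[C@]1(C)CCC[C@]2(C)C(=O)O`, is one of three labdane-type acids that carry a six-heavy-atom side chain on the shared core. In a functional assay on A549 cells (Homo sapiens) for cytotoxicity, read by MTT assay, with a stated time of 48 h (on this read-out higher numbers stand for weaker inhibition and lower numbers for stronger inhibition), compound 3 gives > 40000 nM, which is a limit of the assay rather than a number. Compound 1, `C=C1CC[C@@H]2[C@](C)(CCC[C@]2(C)C(=O)O)[C@H]1CC/C(C)=C/CO`, carries 3-hydroxy-1-methylprop-1-en-1-yl on the same chain. In this assay compound 1 gives > 40000 nM, again a limit. Compound 2, `C=CC(=C)[C@@H](O)C[C@H]1C(=C)CC[C@@H]2[C@]1(C)CCC[C@]2(C)C(=O)O`, carries the third variant of that chain. In this assay compound 2 gives > 40000 nM, also a limit. The three steps among them, a step that the two limits leave unreadable from compound 1 to compound 2, a step that the two limits leave unreadable from compound 1 to compound 3 and a step that the two limits leave unreadable from compound 2 to compound 3, therefore carry no readable size, as the limit of > 40000 nM in this assay, at which 3 of the 3 values shown sit, shows.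

Compound 4, `C=C[C@]1(C)O[C@H]1C[C@H]1C(=C)CC[C@@H]2[C@]1(C)CCC[C@]2(C)C(=O)O`, differs from compound 3 in one place: a group of 6 heavy atoms (5 carbon, 1 oxygen; one three-membered non-aromatic ring with 1 hetero atom) in place of a group of 6 heavy atoms (5 carbon, 1 oxygen; no ring), on a saturated chain carbon bound to a saturated ring carbon. Going by the values given here, no measured step bears on the closing of a hydroxy-bearing chain into a three-membered ring with one hetero atom, and every comparison available ends at the same limit. Nothing in the shown data gives a direction for this change.

On that basis compound 4 is expected to remain close to the limit, with the step of a number no higher from compound 3 to compound 4 (the limit leaves the size open) estimated as no change beyond the scatter. Compound 4 is estimated at 40000 nM, within the range 10000 nM to 100000 nM.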

Compound 4, half-maximal inhibitory concentration: > 40000 nM
Compound 4: only a limit was reported (the forecaster's own chance of this, stated with the estimate: 70%); the middle value sits exactly at the limit.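

In this assay compound 4 gives > 40000 nM, which is again a limit. Going by these compounds alone, its steps from compound 1, compound 2 and compound 3 therefore cannot be read, and no new step emerges: the limit of > 40000 nM in this assay, at which 4 of the 4 values shown sit. The compounds shown leave open whether any of these side-chain changes on the shared core alters cytotoxicity at all.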